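The compounds below may be only part of what the source reports. "The series", "measured", "known", "first", "only" and "open" are said of these compounds alone.

Compound 1 `CC(C)OC(=O)NCCS(=O)(=O)NC(=O)c1ccc(Nc2nc(NC3(c4ccc(Cl)cc4)CC3)nc(OCC(F)(F)F)n2)cc1` was tested in an ADME assay on microsomes from liver (Homo sapiens) for metabolic stability, with a stated time of 10 min (a lower number here means that less of the compound is left, a higher number that more of the compound is left), where compound 1 gives 100%. Within this small set, compound 1 stands highest of three. Compound 2 `CC(C)(C)OC(=O)NCCS(=O)(=O)NC(=O)c1ccc(Nc2nc(NC3(c4ccc(Cl)cc4)CC3)nc(OCC(F)(F)F)n2)cc1` gives 92%, and compound 3 `CN(C)S(=O)(=O)NC(=O)c1ccc(Nc2nc(NC3(c4ccc(Cl)cc4)CC3)nc(OCC(F)(F)F)n2)cc1` gives 86%. The step of a number 8 percentage points lower from compound 1 to compound 2 (within the scatter) lies within the scatter, the step of a number 14 percentage points lower from compound 1 to compound 3 (beyond the scatter) lies modestly beyond it, and the step of a number 6 percentage points lower from compound 2 to compound 3 (within the scatter) again lies within it.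

Compound 4 `O=C(NS(=O)(=O)CCNCc1ccccc1)c1ccc(Nc2nc(NC3(c4ccc(Cl)cc4)CC3)nc(OCC(F)(F)F)n2)cc1` has not yet been measured in this assay. It differs from compound 1 in one place: benzyl in place of isopropoxycarbonyl on an amine nitrogen. Among the compounds with values here, no measured step covers this particular exchange; the closest is the replacement on the sulfonyl sulfur from compound 1 to compound 3, which moved the number only modestly. Since compound 1 already sits at the top of the range shown, any step can only hold or fall. A small downward step is therefore expected for compound 4, estimated as a number 15 percentage points lower from compound 1 to compound 4 (beyond the scatter), giving an expected 85% with a range from 65% to 100%.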

Compound 4, percent of the compound remaining: 99%
Compound 4: the middle estimate sits 14 percentage points below what was measured; measured number inside the range.
By their numbers in this assay, from the lowest: compounds 3, 2, 4 and 1 (each within the scatter of the next, the first and the last beyond it).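

In this assay, benzyl in place of isopropoxycarbonyl on the amine nitrogen gives a number 1 percentage points lower from compound 1 to compound 4 (within the scatter), so at this position a group with an aromatic ring and no hydrogen-bond acceptors reads the same as one with a carbonyl and two oxygens. Benzyl in place of tert-butoxycarbonyl gives the same reading (a number 7 percentage points higher from compound 2 to compound 4 (within the scatter)), whereas 2-(benzylamino)ethyl in place of dimethylamino on the sulfonyl sulfur gives a number 13 percentage points higher from compound 3 to compound 4 (beyond the scatter), the only one of these steps beyond the scatter. Nothing at hand gives a cause for these steps.

Open, going by these compounds, is how this nitrogen would read with a free amine, an acetyl group or a pyridylmethyl group. On these data alone, a substituted benzyl or a longer chain between the sulfonyl sulfur and the amine nitrogen also remains open.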